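Naphthylmethyl amines against substance-K receptor binding: a piperazine amide

This account rests on a few compounds, and the source may have more. Where it says the series, first, only, none or still open, it means among the compounds named here.

Compound 1, `N#CCN(Cc1ccc(Br)cc1)Cc1ccc2ccccc2c1`, in an assay on HEK293 cells for binding affinity to Substance-K receptor (Rattus norvegicus), read by FRET, tested at 10 uM (on this read-out higher numbers stand for more inhibition at the one concentration tested (going by the name of the read-out) and lower numbers for less inhibition), gives 0%.
Compound 2, `COc1ccc(CN(CC#N)Cc2ccccc2)cc1`, in this assay gives 0%.
Compound 3, `CCOC(=O)CCCCN(Cc1ccccc1)Cc1ccc2ccccc2c1`, in this assay gives 0%.

Compound 3 stands level with compounds 1 and 2 at the digits shown: nearest is compound 1, with no change beyond the scatter, and furthest is compound 2, again with no change beyond the scatter. Compound 4, `CN1CCN(C(=O)CN(Cc2ccccc2)Cc2ccc3ccccc3c2)CC1`, has not yet been measured. It differs from compound 3 as follows: (4-methylpiperazin-1-yl)carbonyl in place of 3-(ethoxycarbonyl)propyl on a saturated chain carbon bound to an amine nitrogen. Within the data shown here, with all three measured compounds at the same level and no measured step to lean on, no step beyond the scatter is expected here. The step from compound 3 to compound 4 is estimated at a number 3 percentage points higher from compound 3 to compound 4 (within the scatter). Compound 4 is expected to give 3%, in the range -8% to 15%.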

Compound 4, a percentage reported as inhibition, at one concentration (the size of the read-out at that concentration, not a potency): 0%
Estimate against measurement, compound 4: 3 percentage points above; the range from low to high includes it.
By their numbers in this assay, from the lowest: compounds 1, 2, 3 and 4 (each within the scatter of the next).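

In this assay, putting (4-methylpiperazin-1-yl)carbonyl in place of 3-(ethoxycarbonyl)propyl on a saturated chain carbon bound to an amine nitrogen gives no change at the digits printed from compound 3 to compound 4 (within the scatter). Among these compounds, this is the first step that can be read at this place, and it shows that a piperazine amide and an ethyl ester chain read alike here. No measurement shown bears on the reason for this result. On these data alone, whether a carboxylic acid or a primary amine at this place would register any inhibition stays open. So does whether any other group on the shared core would.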